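The compounds below may be only part of what the source reports. "The series", "measured", "known", "first", "only" and "open" are said of these compounds alone.

Measured compounds in an assay for inhibition of Amine oxidase [flavin-containing] A (Bos taurus), read by fluorescence, with a stated time of 60 min; a higher number here means a weaker inhibitor, a lower number a stronger inhibitor:
Compound 1 `Cc1ccc(C(=O)NNC(=O)Cn2c(=O)c(Cc3ccccc3)nc3ccccc32)cc1` gives 52 nM.
Compound 2 `O=C(Cn1c(=O)c(Cc2ccccc2)nc2ccccc21)NNC(=O)c1ccc(Cl)cc1` gives 64 nM.
Compound 3 `O=C(Cn1c(=O)c(Cc2ccccc2)nc2ccccc21)N/N=C/c1ccc([N+](=O)[O-])cc1` gives 98 nM.

Compound 3 gives the highest number of the measured set, but the steps of a 1.5-fold higher number from compound 2 to compound 3 (0.19 log units; within the scatter) and a 1.9-fold higher number from compound 1 to compound 3 (0.28 log units; within the scatter) are both within the scatter, so no separation between compound 1, compound 2 and compound 3 can be claimed. The step of a 1.2-fold higher number from compound 1 to compound 2 (0.09 log units; within the scatter) is likewise within the scatter.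

Compound 4 `C/C(=N\NC(=O)Cn1c(=O)c(Cc2ccccc2)nc2ccccc21)c1ccc(O)cc1` is not yet measured. Relative to compound 3 the change is a group of 10 heavy atoms (8 carbon, 1 nitrogen, 1 oxygen; one six-membered aromatic ring of carbon only) in place of a group of 11 heavy atoms (7 carbon, 2 nitrogen, 2 oxygen; one six-membered aromatic ring of carbon only), on an amide-type nitrogen; the leaving group carries 2 double bonds outside aromatic rings, 0 hydrogen-bond donors and 3 hydrogen-bond acceptors, the entering group 1 double bond outside aromatic rings, 1 hydrogen-bond donor and 2 hydrogen-bond acceptors.

For the measured compounds named here, the steps that bear on this change are those that swap the group on the amide-type nitrogen: a 1.9-fold higher number from compound 1 to compound 3 (0.28 log units; within the scatter) and a 1.5-fold higher number from compound 2 to compound 3 (0.19 log units; within the scatter). Both stay within the scatter, so the group on this nitrogen has so far not moved the number beyond it. The expected step in this assay is therefore small, with no direction beyond the scatter. Compound 4 is expected to give about 70 nM, within 30 nM to 170 nM, an estimated step of a 1.4-fold lower number from compound 3 to compound 4 (0.15 log units; within the scatter).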

Compound 4, half-maximal inhibitory concentration: 1.6 nM
Estimate against measurement, compound 4: 44-fold (1.64 log units) above; measured number outside the range, below it.
By their numbers in this assay, from the lowest: compound 4; then compounds 1, 2 and 3 (each within the scatter of the next).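

In this assay, for the compounds shown here, the group on the amide-type nitrogen, which had so far moved the number only within the scatter, proves able to move it a long way: a 61-fold lower number from compound 3 to compound 4 (1.79 log units; beyond the scatter), a 40-fold lower number from compound 2 to compound 4 (1.60 log units; beyond the scatter) and a 33-fold lower number from compound 1 to compound 4 (1.51 log units; beyond the scatter), all three beyond the scatter. This position is therefore not indifferent to what it carries, and the three earlier groups, whose numbers lie within the scatter of one another, gave no sign of the reach that the group of compound 4 reveals. No measurement at hand speaks to the origin of this step.

The group of compound 4 differs from that of compound 3 in two features at once, a hydroxyl where compound 3 has a nitro and a methyl on the carbon of the carbon-nitrogen double bond, so the compounds shown do not tell which of the two carries the step or whether both are needed. From the compounds shown here alone, whether a methoxy, an amine or a carboxylic acid in place of the hydroxyl would keep the number this low also remains open.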